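The compounds below may be only part of what the source reports. "The series", "measured", "known", "first", "only" and "open" are said of these compounds alone.

Compound 1 `Cc1ccc(C(C)C)c(OCCSC(=S)N[C@H]2CCOC2=O)c1`: > 64000 nM
Compound 2 `O=C(COc1ccc(C(=O)/C=C/c2ccc(F)c(F)c2)cc1)N[C@H]1CCOC1=O`: 21900 nM

In a functional assay on PC-3 cells (Homo sapiens) for antiproliferative activity, read by MTT assay, with a stated time of 72 h (a lower number here means a stronger inhibitor, a higher number a weaker inhibitor), compound 2 gives 21900 nM. Among the two values shown, this is the only actual number. The value of compound 1 in this assay is a limit of the assay, > 64000 nM. This is summarised as the limit of > 64000 nM in this assay, at which 1 of the 2 values shown sits. No step between compound 1 and compound 2 is computed, since the two structures differ in many places at once, and only their two values are shown. Compound 3 `O=C(COc1ccc(C(=O)/C=C/c2cccc(Br)c2)cc1)N[C@H]1CCOC1=O` has not yet been measured in this assay. Compound 3 differs from compound 2 by 3-bromophenyl in place of 3,4-difluorophenyl on a double-bonded chain carbon bound to a double-bonded chain carbon. Among the compounds with values here, no measured pair in the set isolates this change, so there is no computed step to lean on. With only the number for compound 2 as an anchor, compound 3 is expected to land close to compound 2, and the estimated step of a 1.4-fold lower number from compound 2 to compound 3 (0.14 log units; within the scatter) is expected to stay within the scatter of repeated measurements. Compound 3 is therefore estimated at 16000 nM, with a range from 5000 nM to 50000 nM.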

Compound 3, half-maximal inhibitory concentration: 7890 nM
Beside the measured number, compound 3's estimate is 2.0-fold (0.31 log units) above it; the range from low to high includes it.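

In this assay, putting 3-bromophenyl in place of 3,4-difluorophenyl on a double-bonded chain carbon bound to a double-bonded chain carbon gives a 2.8-fold lower number from compound 2 to compound 3 (0.44 log units; beyond the scatter), a modest step but the first in the set that can be read, and it shows that the number responds to the aryl group at this position while the rest of the structure stays the same. Compound 1 could not show this: it differs from the other compounds in many places at once, and its value of > 64000 nM is a limit of the assay and not a number. Nothing among the measurements shown accounts for why the bromine-bearing ring gives the lower number.

This single exchange removes two fluorines and brings in one bromine, so the compounds shown do not separate the loss of the fluorines from the gain of the bromine. Going by these compounds, a plain phenyl, a 3-chlorophenyl or a 4-bromophenyl ring at this place would be needed to tell these apart, and whether a ring carrying an amine or a carboxylic acid would fit the same trend remains open.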